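Working notes: exchanging the chloro and cyano positions

This account rests on a few compounds, and the source may have more. Where it says the series, first, only, none or still open, it means among the compounds named here.

Measured in a functional assay on MCF7 cells (Homo sapiens) for antiproliferative activity, read by CellTiter-Glo, with a stated time of 5 days; on this read-out higher numbers stand for weaker inhibition and lower numbers for stronger inhibition:
- compound 1 `N#Cc1cc(Cl)ccc1/C(=C(\c1ccc(/C=C/C(=O)O)cc1)c1ccc2nccn2c1)C1CCC1` gives 5.9 nM
- compound 2 `N#Cc1ccc(/C(=C(\c2ccc(/C=C/C(=O)O)cc2)c2ccc(-c3cn[nH]c3)cc2)C2CCC2)c(Cl)c1` gives 2.2 nM

Compound 2 has the lower of these two numbers, and its gap to compound 1 lies beyond the scatter. Compound 3 `N#Cc1cc(Cl)ccc1/C(=C(\c1ccc(/C=C/C(=O)O)cc1)c1ccc(-c2cn[nH]c2)cc1)C1CCC1` is unmeasured and differs from compound 2 as follows: 4-chloro-2-cyanophenyl in place of 2-chloro-4-cyanophenyl on a double-bonded chain carbon bound to a double-bonded chain carbon and a saturated ring carbon. Within the data shown here, no measured pair isolates this change, so any expectation is tentative. In this assay, no step beyond the scatter is expected, since compound 1, which also carries 4-chloro-2-cyanophenyl, gives 5.9 nM. The expected change is a 1.4-fold higher number from compound 2 to compound 3 (0.13 log units; within the scatter). The estimate for compound 3 is 3 nM, with a range of 1.2 nM to 8 nM.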

Compound 3, half-maximal inhibitory concentration: 4.4 nM
Compound 3: middle estimate off by 1.5-fold (0.17 log units), on the low side; measured number inside the range.
By their numbers in this assay, from the lowest: compounds 2, 3 and 1 (each within the scatter of the next, the first and the last beyond it).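

In this assay, among these compounds, 4-chloro-2-cyanophenyl in place of 2-chloro-4-cyanophenyl gives a 2.0-fold higher number from compound 2 to compound 3 (0.30 log units; within the scatter), so exchanging the chloro and nitrile positions on this ring leaves no step that can be told from the scatter. Compounds 1 and 2 differ in two places and could not separate this change from the other one, which gives a 1.3-fold lower number from compound 1 to compound 3 (0.13 log units; within the scatter). No measurement shown offers a reason for either step. Still open, on these data alone, is whether a fluoro group in place of the chloro, or an amide in place of the carboxylic acid, would keep numbers of this size.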